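The compounds below may be only part of what the source reports. "The series", "measured", "known", "first", "only" and "open" are said of these compounds alone.

Working notes on the ester series.

All three measured compounds share one core and differ only in the ester chain and in the group beside it on the core. Compound 1 `CCCCc1nc(C(C)C)c(CC(=O)OC)c(=O)n1Cc1ccc(-c2ccccc2-c2noc(=O)[nH]2)cc1` gives 9.4% in an ADME assay on microsomes from liver (Mus musculus) for metabolic stability, with a stated time of 30 min; on this read-out higher numbers stand for a more stable compound and lower numbers for a less stable compound. Compound 2 `CCCCc1nc(C(C)C)c(CC(=O)OCCC)c(=O)n1Cc1ccc(-c2ccccc2-c2noc(=O)[nH]2)cc1` gives 12.6% in this assay, so that a number 3.2 percentage points higher from compound 1 to compound 2 (within the scatter). Compound 3 `CCCCc1nc(C)c(CC(=O)OC(C)C)c(=O)n1Cc1ccc(-c2ccccc2-c2noc(=O)[nH]2)cc1` gives 4% in this assay; this is the lowest of the three numbers, yet its gaps to compound 1 and to compound 2 are both within the scatter, so no order among the three can be claimed.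

Compound 4 `CCCCc1nc(C)c(CC(=O)OC2CCCCC2)c(=O)n1Cc1ccc(-c2ccccc2-c2noc(=O)[nH]2)cc1` has not been measured in this assay. Its difference from compound 3 is cyclohexyl in place of isopropyl on an oxygen next to a carbonyl group. Among the measured compounds shown here, the only measured step at the same oxygen is a number 3.2 percentage points higher from compound 1 to compound 2 (within the scatter), a change of the ester chain that stayed within the scatter. For the measured compounds named here, no measured step covers a ring entering at this position, and no measured compound carries a cyclohexyl ester. On this basis the step is expected to stay within the scatter, with no direction beyond it; the estimate means a number 2 percentage points higher from compound 3 to compound 4 (within the scatter). For compound 4 the expected value in this assay is 6%, in a range from 1% to 18%.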

Compound 4, percent of the compound remaining: 10.7%
For compound 4 the middle estimate is 4.7 percentage points below the measured one; the range from low to high includes it.
By their numbers in this assay, from the lowest: compounds 3, 1, 4 and 2 (each within the scatter of the next).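

In this assay, among the compounds shown here, cyclohexyl in place of isopropyl on an oxygen next to a carbonyl group gives a number 6.7 percentage points higher from compound 3 to compound 4 (within the scatter), the first reading for a ring at this oxygen. Going from 3 to 6 heavy atoms and adding a six-membered non-aromatic ring of carbon only therefore leaves the read-out within the scatter, as the open-chain change did with a number 3.2 percentage points higher from compound 1 to compound 2 (within the scatter), and neither step gives a direction that can be claimed. Nothing available bears on what lies behind either step.

The compounds shown leave open whether any change at this oxygen moves the read-out beyond the scatter, for instance an ester chain carrying an amine, a phenyl ester, or a carboxylic acid in place of the ester. They also leave open whether the cyclohexyl ester would read the same with the isopropyl group of compound 1 on the shared core, since this change has been read on one background only.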